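4-Chlorophenyl in place of furan-2-yl in compound 2

A few compounds are considered here, and "the series" means these few. Any claim that something is new, unique, unknown or untested is made for them only; others in the source may bear on it.

Within the data shown here, in a functional assay on DU-145 cells (Homo sapiens) for cytotoxicity, read by ELISA, with a stated time of 4 days (a lower number here means a stronger inhibitor, a higher number a weaker inhibitor), compound 1 (`Cc1ccsc1-c1cc(-c2ccoc2)cc(-c2ccc(Cl)cc2)n1`) reads 20100 nM while compound 2 (`Cc1ccsc1-c1cc(-c2ccc(Cl)o2)cc(-c2ccco2)n1`) reads 27300 nM within the scatter of compound 1, so compound 2 stands level with the only other measured compound. Compound 3 (`Cc1ccsc1-c1cc(-c2ccc(Cl)o2)cc(-c2ccc(Cl)cc2)n1`) carries 4-chlorophenyl in place of furan-2-yl on an aromatic carbon next to the ring nitrogen. Among the measured compounds shown here, compound 1 carries 4-chlorophenyl too and reads 20100 nM but no measured pair isolates this change, so no step beyond the scatter is expected in this assay for compound 3. The estimate for compound 3 is 21000 nM (expected range 9000 nM to 50000 nM).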

Compound 3, half-maximal inhibitory concentration: 21900 nM
Estimate against measurement, compound 3: 1.0-fold (0.02 log units) below, and the stated range covers the measured number.
By their numbers in this assay, from the lowest: compounds 1, 3 and 2 (each within the scatter of the next).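

In this assay 4-chlorophenyl in place of furan-2-yl next to the ring nitrogen gives a 1.2-fold lower number from compound 2 to compound 3 (0.10 log units; within the scatter) and leaves the reading flat at this position. The other single change, 5-chlorofuran-2-yl in place of furan-3-yl on an aromatic carbon, gives a 1.1-fold higher number from compound 1 to compound 3 (0.04 log units; within the scatter) and is equally flat, so neither change has yet moved the number. Nothing at hand accounts for this flatness. Only aromatic rings stand on the carbon next to the ring nitrogen in the compounds shown; how an amine or a carboxylic acid there would read stays open.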